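Notes on an aminotriazine series: phenylpropoxy to methoxyethoxy

The compounds below may be only part of what the source reports. "The series", "measured", "known", "first", "only" and "open" are said of these compounds alone.

Going by the values given here, compound 2 `CCCCNc1nc(N)nnc1OCCCc1ccccc1` holds the second highest of the three numbers so far in an assay on isolated protein for agonist activity at Toll-like receptor 8 (Homo sapiens) (a higher number here means that more compound is needed for the effect, a lower number that less compound is needed), giving 1930 nM. Its nearest neighbour is compound 1 `CCCCNc1nc(N)nnc1OCc1ccccc1F`, which in this assay gives 560 nM, a gap beyond the usual scatter. The furthest is compound 3 `CCOC(=O)C1=Cc2ccc(-c3cccc(C#N)c3)cc2N=C(N)C1`, built on a different core, which in this assay gives 15000 nM, again beyond the scatter. Among the compounds with values here, no two measured compounds differ in a single place, so no measured step exists to lean on.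

Compound 4 `CCCCNc1nc(N)nnc1OCCOC` is not yet measured. It differs from compound 2 by methoxy in place of benzyl on a saturated chain carbon, two bonds along the chain from an oxygen on an aromatic ring. The aromatic ring at the end of the side chain is removed and a short chain with one further hydrogen-bond acceptor remains. Among the three measured compounds, both of the lower numbers belong to compounds carrying an aromatic ring on that side chain, but nothing measured tells how the series responds to its removal.

The expectation is a moderate loss: compound 4 is estimated at 5000 nM in this assay, within 1500 nM to 20000 nM. The expected step from compound 2 to compound 4 is a 2.6-fold higher number from compound 2 to compound 4 (0.41 log units; beyond the scatter), an upward move beyond the scatter.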

Compound 4, half-maximal effective concentration: 1000 nM
Compound 4: the middle estimate sits 5.0-fold (0.70 log units) above what was measured, and the stated range ends above it.
By their numbers in this assay, from the lowest: compounds 1, 4 and 2 (each within the scatter of the next, the first and the last beyond it); then compound 3.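

In this assay the aromatic ring at the end of the side chain proves dispensable in this series: the step is a 1.9-fold lower number from compound 2 to compound 4 (0.29 log units; within the scatter) for methoxy in place of benzyl, and a 1.8-fold higher number from compound 1 to compound 4 (0.25 log units; within the scatter) for methoxymethyl in place of 2-fluorophenyl. Until now, both of the lower numbers belonged to compounds carrying such a ring on that side chain, whereas compound 4 carries none and stays within the scatter of compound 1 and of compound 2, so on these three compounds the ring is not needed to hold the number. No measurement at hand accounts for this tolerance.

Still open, going by these compounds, is whether the side chain tolerates an amine or a carboxylic acid at its end, or a longer ether chain. Also open, on these data alone, is whether any chain without a ring goes beyond the scatter of compound 4 in either direction.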